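The source may report more compounds than this note shows. Statements on the series, on what has been measured and on what is new or still open speak of the compounds shown alone.

Compound 2 `Cc1ccc(OCC(=O)N(Cc2cccs2)C2COC2)cc1` gives 23000 nM in an assay on HEK293 cells for agonist activity at transient receptor potential cation channel subfamily M member 8 (Homo sapiens), read by fluorescence and calcium flux, with a stated time of 15 min (on this read-out lower numbers stand for an effect already at smaller amounts and higher numbers for an effect only at larger amounts of compound), and stands highest of the two numbers measured; its nearest neighbour is compound 1 `Cc1ccc(OCC(=O)N(Cc2cccs2)c2nccs2)cc1`, which in this assay gives 2240 nM. Going by the values given here, the single measured step, a 10-fold higher number from compound 1 to compound 2 (1.01 log units; beyond the scatter), concerns the same amide-type nitrogen that is varied next. Compound 3 `Cc1ccc(OCC(=O)N(C)Cc2cccs2)cc1` differs from compound 2 by methyl in place of oxetan-3-yl on an amide-type nitrogen. Among the compounds with values here, no measured step shows methyl on this nitrogen, so the one step available bears on it only indirectly: replacing the aromatic ring with oxetan-3-yl cost much, and methyl is a further departure from the aromatic ring. Whether the small group repeats the loss or recovers part of it cannot be read from compound 1 and compound 2 alone; a step of modest size in either direction is expected, a 1.5-fold lower number from compound 2 to compound 3 (0.19 log units; within the scatter). The value for compound 3 is estimated at 15000 nM, within a range from 4000 nM to 60000 nM.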

Compound 3, half-maximal effective concentration: 400 nM
The estimate for compound 3 lay 38-fold (1.57 log units) above the measured number; the whole stated range lies above it.
By their numbers in this assay, from the lowest: compound 3; then compound 1; then compound 2.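

In this assay, the amide-type nitrogen gives the lowest number here with methyl, the smallest group shown: a 58-fold lower number from compound 2 to compound 3 (1.76 log units; beyond the scatter), and a 5.6-fold lower number from compound 1 to compound 3 (0.75 log units; beyond the scatter), so neither ring on this nitrogen is required for the effect. The number does not simply rise with the size of the group, and compound 1 goes against such a trend, since its 1,3-thiazol-2-yl group still gives a 10-fold higher number from compound 1 to compound 2 (1.01 log units; beyond the scatter) in favour of compound 1 over the oxetan-3-yl group of compound 2. Nothing measured here accounts for these differences.

Open, as far as these compounds go, is whether ethyl, cyclopropyl or a longer chain on this nitrogen holds the number of compound 3, and whether the amide hydrogen in place of methyl does the same. Also open, from the compounds shown here alone, is whether the methyl result carries over when the shared core is changed elsewhere.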